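Changing one aryl group in an antiproliferative series

This account rests on a few compounds, and the source may have more. Where it says the series, first, only, none or still open, it means among the compounds named here.

Compound 3 `C#Cc1ccc(NC(=O)Nc2cccc(-c3nc(-c4ccc(NC(=O)c5cccnc5)cc4Cl)no3)c2)cc1` is tested in a functional assay on MDA-MB-231 cells (Homo sapiens) for antiproliferative activity, read by MTT assay, with a stated time of 72 h (a higher number here means a weaker inhibitor, a lower number a stronger inhibitor), and gives only the assay's limit, > 10000 nM. Compound 1 `NS(=O)(=O)c1ccc(NC(=O)Nc2cccc(-c3nc(-c4ccc(NC(=O)c5cccnc5)cc4Cl)no3)c2)cc1` likewise reaches only the limit, > 10000 nM. Compound 2 `COc1ccc(NC(=O)Nc2cccc(-c3nc(-c4ccc(NC(=O)c5cccnc5)cc4Cl)no3)c2)cc1C(F)(F)F` gives a number, 1700 nM. Compound 4 `CS(=O)(=O)Nc1ccc(NC(=O)Nc2cccc(-c3nc(-c4ccc(NC(=O)c5cccnc5)cc4Cl)no3)c2)cc1Br` differs from compound 3 in one place: 3-bromo-4-(methanesulfonamido)phenyl in place of 4-ethynylphenyl on an amide-type nitrogen. The measured steps that bear on this are an at least 5.8-fold higher number from compound 2 to compound 3 (0.76 log units; beyond the scatter) and an at least 5.8-fold lower number from compound 1 to compound 2 (0.76 log units; beyond the scatter), while the step that the two limits leave unreadable from compound 1 to compound 3 cannot be read. Compound 1, which carries a sulfamoyl group, sits at the limit (the limit of > 10000 nM in this assay, at which 2 of the 3 values shown sit), and compound 4 brings in a methanesulfonamido group, so a weak result is expected. Compound 4 is estimated at 8000 nM (range 2000 nM to 30000 nM), which means an expected step of an at least 1.2-fold lower number from compound 3 to compound 4 (0.09 log units; that floor lies within the scatter).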

Compound 4, half-maximal inhibitory concentration: 700 nM
The estimate for compound 4 lay 11-fold (1.06 log units) above the measured number; the measured number lies below the stated range.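

On the amide-type nitrogen in this assay, the 3-bromo-4-(methanesulfonamido)phenyl group carries a sulfonyl unit, as the 4-sulfamoylphenyl group does, yet the change gives an at least 14-fold lower number from compound 1 to compound 4 (1.15 log units; beyond the scatter) and an at least 14-fold lower number from compound 3 to compound 4 (1.15 log units; beyond the scatter). Going by these compounds alone, it also goes past the only earlier compound with a real number, with a 2.4-fold lower number from compound 2 to compound 4 (0.39 log units; beyond the scatter). So a sulfonyl-bearing aryl group need not stay at the limit, which still holds the other two compounds: the limit of > 10000 nM in this assay, at which 2 of the 4 values shown sit.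

Bromine and methanesulfonamido enter together, so their separate contributions remain open. Also open, going by these compounds, is what a 4-aminophenyl or 4-carboxyphenyl group would give here.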